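The compounds below may be only part of what the source reports. "The series", "measured", "known", "first", "only" and "open" are said of these compounds alone.

Measured in a physicochemical assay for lipophilicity, at pH 7.4; on this read-out higher numbers stand for higher lipophilicity and lower numbers for lower lipophilicity:
- compound 1 `Cc1cc(C(=O)O)nn1Cc1cc(Br)ccc1OCc1ccccc1`: 1.2
- compound 2 `CNC(=O)c1cc(C)n(Cc2cc(Cl)ccc2OCc2ccccc2)n1`: > 3.7

Compound 2 stands at a limit of the measurement, not at a number: > 3.7. Its exact position is therefore unknown, though it clearly lies higher than compound 1.

Compound 3 `Cc1cc(C(=O)Nc2cccc(F)c2)nn1Cc1cc(Cl)ccc1OCc1ccccc1` carries 3-fluorophenyl in place of methyl on an amide-type nitrogen. Among the measured compounds shown here, no measured pair shows this change, so the expectation rests on the structural change alone. A clear upward move in this assay is expected: a step that the limit leaves unreadable from compound 2 to compound 3. For compound 3 the estimated value is 4.7, with an expected range from 4 to 5.5.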

Compound 3, distribution coefficient: 2.8
For compound 3 the middle estimate is 1.90 log units above the measured one, outside the stated range (below it).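

Placing 3-fluorophenyl in place of methyl on an amide-type nitrogen gives a number at least 0.90 log units lower from compound 2 to compound 3 (beyond the scatter) in this assay and thereby shows that adding an aromatic ring at this position does not have to raise this read-out. The direction of the change is now known, but its full size is not, because the entry for compound 2 is a limit and not a number: the limit of > 3.7 in this assay, at which 1 of the 3 values shown sits.

On these data alone, whether an unsubstituted phenyl or a longer chain such as butyl on the same nitrogen would move the read-out in the same direction remains open.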